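The compounds below may be only part of what the source reports. "The series", "measured", "known", "first", "only" and "open" are said of these compounds alone.

Two compounds of the series have been run in a functional assay on the whole organism for inhibition, with Rattus norvegicus as the target, read by paw edema, with stated times of 1 h and 6 h, at a dose of 0.03 mg/kg by the oral route (on this read-out lower numbers stand for less inhibition and higher numbers for more inhibition at the one dose given (going by the name of the read-out)), so far. Compound 1 `CC1=NN(C(=O)c2cc3ccccc3oc2=O)C(=O)C1CNc1c(O)cc(S(=O)(=O)O)c2ccccc12` gives 45.3% in this assay, while compound 2 `CC1=NN(C(=O)c2cc3ccccc3oc2=O)C(=O)C1CNc1ccc(Cl)cc1` gives 71.5%, the higher of the two numbers, a gap beyond the scatter. Compound 3 `CC1=NN(C(=O)c2cc3ccccc3oc2=O)C(=O)C1CNc1ccc([N+](=O)[O-])cc1` is the next to be read. It differs from compound 2 in one place: nitro in place of chloro on an aromatic carbon. Going by the values given here, no measured pair shows this change, so no step beyond the scatter is expected in this assay, with the estimate for compound 3 set at 66% (range 48% to 84%). The expected step is a number 5.5 percentage points lower from compound 2 to compound 3 (within the scatter).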

Compound 3, a percentage reported as inhibition, in the whole organism at one dose (the size of the read-out at that dose, not a potency): 72%
Compound 3: the middle estimate sits 6 percentage points below what was measured; low and high end bracket the measured number.
By their numbers in this assay, from the lowest: compound 1; then compounds 2 and 3 (each within the scatter of the next).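

In this assay, going by these compounds alone, nitro in place of chloro gives a number 0.5 percentage points higher from compound 2 to compound 3 (within the scatter), the first reading of a single change at this aromatic carbon, para to a large group. The position therefore accepts either group at this one dose with no step beyond the scatter, and 4-chlorophenyl and 4-nitrophenyl cannot be told apart here. No measurement at hand bears on why the two read alike. Still open, as far as these compounds go, is how an amine or a carboxylic acid at this carbon would read. Also open, from the compounds shown here alone, is whether a longer chain there would hold the reading.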